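The source may hold more compounds than are shown below. What is called first, only, known or untested is meant among the compounds shown, and "the series" means these compounds.

Measured in an ADME assay on THP-1 cells (Homo sapiens) for cytotoxicity; on this read-out lower numbers stand for higher toxicity in this test and higher numbers for lower toxicity in this test:
Compound 1 `O=C(Nc1ccc(Cl)cc1)c1c(NC(=O)C(F)(F)F)sc2c1CCCCC2`: > 50000 nM
Compound 2 `N#Cc1ccc(NC(=O)c2c(NC(=O)C(F)(F)F)sc3c2CCCCC3)cc1`: 9110 nM
Compound 3 `COc1cccc(NC(=O)c2c(NC(=O)C(F)(F)F)sc3c2CCCCC3)c1`: 37600 nM

The value of compound 1, > 50000 nM, is a limit and not a number. Of the two true numbers, compound 3 has the higher, at 37600 nM.

Compound 4 `CC(C)(C)NC(=O)c1c(NC(=O)C(F)(F)F)sc2c1CCCCC2` is next, with tert-butyl in place of 3-methoxyphenyl on an amide-type nitrogen. The nearest precedents change the group at this same place: a 4.1-fold higher number from compound 2 to compound 3 (0.62 log units; beyond the scatter), and an at least 1.3-fold lower number from compound 1 to compound 3 (0.12 log units; that floor lies within the scatter). The remaining step, an at least 5.4-fold lower number from compound 1 to compound 2 (0.73 log units; beyond the scatter), shows that a single change on the aromatic ring can also move the read-out. Going by the values given here, all three measured compounds carry an aromatic group on this nitrogen, so no measured step shows the effect of tert-butyl there.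

With so little precedent, no clear direction can be assigned, and no step beyond the scatter is expected. The expected change is a 1.3-fold lower number from compound 3 to compound 4 (0.10 log units; within the scatter). For compound 4 the estimated value is 30000 nM, with an expected range of 10000 nM to 70000 nM.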

Compound 4, half-maximal cytotoxic concentration: > 50000 nM
Compound 4: a limit, no number; the forecaster's own chance of this, stated with the estimate: 35%; middle value at least 1.6-fold (0.22 log units) from the limit.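

In this assay compound 4 stands as > 50000 nM, a limit and not a number: the limit of > 50000 nM in this assay, at which 2 of the 4 values shown sit.

Going by these compounds alone, with tert-butyl, a group without a ring enters this amide-type nitrogen for the first time, and an at least 5.4-fold higher number from compound 2 to compound 4 (0.73 log units; beyond the scatter), while an at least 1.3-fold higher number from compound 3 to compound 4 (0.12 log units; that floor lies within the scatter). An aromatic ring on this nitrogen is therefore not needed for a read-out at the limit, and replacing 4-cyanophenyl with tert-butyl shifts the number beyond the scatter, whereas the floor of the step from 3-methoxyphenyl does not clear it; the step between compound 1 and compound 4 cannot be read, as both ends are limits.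

Going by these compounds, how far beyond the limit compound 4 lies stays open, so tert-butyl cannot be ranked against 4-chlorophenyl. Also open, on these data alone, is where a carboxylic acid or a longer chain on this nitrogen would fall.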